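Swapping a dichlorobenzyl for a methoxybenzyl on the shared core

A few compounds are considered here, and "the series" means these few. Any claim that something is new, unique, unknown or untested is made for them only; others in the source may bear on it.

Compound 1 `Nc1cc(N)c2nc(-c3ccccc3)c(NCc3ccc(Cl)c(Cl)c3)nc2c1` carries a 3,4-dichlorobenzyl group on an amine nitrogen of its shared core. In a functional assay on K562 cells (Homo sapiens) for inhibition, read by sulforhodamine B assay, with a stated time of 48 h (on this read-out higher numbers stand for weaker inhibition of growth and lower numbers for stronger inhibition of growth), compound 1 gives 17800 nM. Compound 2 `CCOC(=O)[C@H](CCC(=O)O)NC(=O)c1ccc(Sc2nc3cc(N)cc(N)c3nc2-c2ccccc2)cc1` replaces that benzylamine with a sulfur-linked benzamide that ends in an ester-capped acid chain; in this assay compound 2 gives 24500 nM, and the two numbers sit within the usual scatter of each other, so no order between them can be claimed. Compound 3 `COc1cc(CNc2nc3cc(N)cc(N)c3nc2-c2ccccc2)cc(OC)c1OC` carries a 3,4,5-trimethoxybenzyl group in the same place. In this assay compound 3 is reported only as a limit, < 50200 nM, not as a number. That limit is the limit of < 50200 nM in this assay, at which 1 of the 3 values shown sits.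

Compound 4 `COc1ccc(CNc2nc3cc(N)cc(N)c3nc2-c2ccccc2)cc1` has not yet been measured. It differs from compound 1 in one place: 4-methoxyphenyl in place of 3,4-dichlorophenyl on a saturated chain carbon bound to a nitrogen on an aromatic ring. Among the compounds with values here, no measured pair shows this change on its own, so the expected step can only be inferred from the three values above. A methoxy-bearing benzyl group in compound 3 gave only the limit (the limit of < 50200 nM in this assay, at which 1 of the 3 values shown sits), which points toward weaker growth inhibition than compound 1 rather than stronger. The expected step from compound 1 to compound 4 is therefore a 1.6-fold higher number from compound 1 to compound 4 (0.20 log units; within the scatter), a modest move toward weaker inhibition, possibly no larger than the scatter. Compound 4 is estimated to give 28000 nM in this assay, with a likely range from 9000 nM to 80000 nM.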

Compound 4, concentration for total growth inhibition: 97700 nM
Beside the measured number, compound 4's estimate is 3.5-fold (0.54 log units) below it, and the stated range ends below it.
By their numbers in this assay, from the lowest: compounds 1 and 2 (each within the scatter of the next); then compound 4.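

Within the data shown here, the change from 3,4-dichlorobenzyl to 4-methoxybenzyl is the first change at this position that can be read on its own, and in this assay it gives a 5.5-fold higher number from compound 1 to compound 4 (0.74 log units; beyond the scatter). With the rest of the molecule unchanged, the group on this saturated chain carbon bound to a nitrogen on an aromatic ring clearly matters, and of these two groups the 3,4-dichlorophenyl one goes with the stronger inhibition of growth. Compound 3, which also carries methoxy groups on its benzyl ring, still cannot be set in this comparison, as it is reported only as a limit and not as a number: the limit of < 50200 nM in this assay, at which 1 of the 4 values shown sits.

This single step changes two things at once, taking away both chlorines and adding a methoxy, so it cannot tell which of them matters more. On these data alone, a plain unsubstituted benzyl group or a 4-chlorobenzyl group on the same core would help separate the two, and it remains open whether any group at this position could take the number well under that of compound 1.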